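One sulfonamide swap starting from a limit

The source may hold more compounds than are shown below. What is called first, only, known or untested is meant among the compounds shown, and "the series" means these compounds.

Compound 1 `CC(=O)OC[C@H]1O[C@@H](n2cc(CN(c3ccc(C#N)cc3)S(C)(=O)=O)nn2)[C@H](OC(C)=O)[C@@H](OC(C)=O)[C@@H]1OC(C)=O`: 215000 nM
Compound 2 `COC(=O)CN(Cc1cn([C@@H]2O[C@H](COC(C)=O)[C@@H](OC(C)=O)[C@H](OC(C)=O)[C@H]2OC(C)=O)nn1)S(C)(=O)=O`: > 250000 nM

Both readings come from a functional assay on MDA-MB-231 cells (Homo sapiens) for antiproliferative activity, read by XTT assay, with a stated time of 48 h; on this read-out higher numbers stand for weaker inhibition and lower numbers for stronger inhibition. Compound 2 gives > 250000 nM, which is a limit of the assay and not a number. Its place on the scale is therefore (the limit of > 250000 nM in this assay, at which 1 of the 2 values shown sits).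

Compound 3 `CCS(=O)(=O)N(Cc1cn([C@@H]2O[C@H](COC(C)=O)[C@@H](OC(C)=O)[C@H](OC(C)=O)[C@H]2OC(C)=O)nn1)c1ccccc1` changes the group on the saturated chain carbon of compound 2: (ethylsulfonyl)(phenyl)amino in place of ((methoxycarbonyl)methyl)(methylsulfonyl)amino on a saturated chain carbon bound to an aromatic carbon.

Going by the values given here, the only measured step bearing on this is an at least 1.1-fold higher number from compound 1 to compound 2 (0.06 log units; that floor lies within the scatter). That step swapped 4-cyanophenyl on a sulfonamide nitrogen for (methoxycarbonyl)methyl. Compound 3 again has a phenyl on that nitrogen, so it resembles compound 1, which gives 215000 nM. Only a small move towards lower numbers, meaning slightly stronger inhibition, is expected, and the estimated change is an at least 1.2-fold lower number from compound 2 to compound 3 (0.09 log units; that floor lies within the scatter). For compound 3 the estimated value is 200000 nM, with an expected range from 90000 nM to 300000 nM.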

Compound 3, half-maximal inhibitory concentration: 155000 nM
Beside the measured number, compound 3's estimate is 1.3-fold (0.11 log units) above it; low and high end bracket the measured number.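

Putting (ethylsulfonyl)(phenyl)amino in place of ((methoxycarbonyl)methyl)(methylsulfonyl)amino on a saturated chain carbon bound to an aromatic carbon gives an at least 1.6-fold lower number from compound 2 to compound 3 (0.20 log units; that floor lies within the scatter). Compound 2 stands at a limit of the assay and not at a number: the limit of > 250000 nM in this assay, at which 1 of the 3 values shown sits. The new result therefore shows that this swap turns a limit into a measured number in this assay, although the step is only a floor and does not establish a real gain in inhibition.

On these data alone, it remains open how far compound 2 truly lies from compound 3, and whether the phenyl or the ethylsulfonyl matters more within this swap. As far as these compounds go, it is also open how an amine or a carboxylic acid on the group attached to the sulfonamide nitrogen, or a longer chain on the sulfonyl, would read here.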